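Removing a Methyl Ether on a Triazole Carbamate Scaffold

The compounds below may be only part of what the source reports. "The series", "measured", "known", "first", "only" and "open" are said of these compounds alone.

Measured so far:
compound 1, `COC(c1ccc(F)cc1)(c1ccc(F)cc1)c1cnn(C(=O)N2CCCCC2Cc2ccccc2)n1`, > 10000 nM
compound 2, `O=C(N1CCCCC1Cc1ccccc1)n1ncc(C(O)(c2ccccn2)c2ccccn2)n1`, 3160 nM

Of the compounds shown here, two of this set have been measured in an assay on isolated protein for inhibition of Monoacylglycerol lipase ABHD6 (Homo sapiens), read by fluorescence; on this read-out lower numbers stand for stronger inhibition and higher numbers for weaker inhibition. For compound 1, the value > 10000 nM is a limit of the assay rather than a number, and so compound 1 sits at the limit of > 10000 nM in this assay, at which 1 of the 2 values shown sits. Compound 2 gives 3160 nM in this assay, a real number and the only one in the set so far.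

The next compound, compound 3, `O=C(N1CCCCC1Cc1ccccc1)n1ncc(C(O)(c2ccc(F)cc2)c2ccc(F)cc2)n1`, is compound 1 with one change: hydrogen in place of methyl on an oxygen on a saturated carbon, or read one bond further out, methoxy to hydroxy. For the measured compounds named here, no measured pair shows this exact step, so its size has to be guessed. Compound 1 is known only as a limit, so the step from compound 1 to compound 3 in this assay cannot be quantified from the data. Compound 3 is expected to land near compound 1 or somewhat toward stronger inhibition. Compound 2, at 3160 nM, is the only anchor for a numbered value in this series. The step of an at least 2.0-fold lower number from compound 1 to compound 3 (0.30 log units; that floor lies within the scatter) is therefore an expectation toward stronger inhibition, but a tentative one. Compound 3 is estimated at 5000 nM, with a likely range from 1500 nM to 20000 nM.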

Compound 3, half-maximal inhibitory concentration: 25.1 nM
Compound 3: the middle estimate sits 200-fold (2.30 log units) above what was measured; the measured number lies below the stated range.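

At the oxygen on a saturated carbon, this single small change decides whether the series has real activity: in this assay, going from methoxy to hydroxy gives an at least 390-fold lower number from compound 1 to compound 3 (2.60 log units; beyond the scatter) with only one methyl leaving and a hydrogen entering. Compound 1 gives > 10000 nM as a limit of the assay and not as a number. The step is therefore a floor, and its full size cannot be read from these values: the limit of > 10000 nM in this assay, at which 1 of the 3 values shown sits.

The compounds shown leave open whether the gain comes from the hydroxy itself or simply from losing the methyl, a question that an amine or a plain hydrogen in place of the hydroxy, or an ethyl or acetyl group on the oxygen, would help to settle. For the compounds shown here, whether methoxy to hydroxy has a similar effect on other members, such as compound 2, also stays open, since the pair of compound 1 and compound 3 is the only example of this change here.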